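The compounds below may be only part of what the source reports. "The series", "measured", "known", "first", "only" and "open" are said of these compounds alone.

Measured so far:
compound 1, `NC(=O)/C=C/c1ccncc1-c1ccc2ccccc2c1`, 10.5 nM in an assay on a protein complex for inhibition of CDK8/Cyclin C (Homo sapiens), with a stated time of 1 h; a lower number here means a stronger inhibitor, a higher number a weaker inhibitor;
compound 2, `CC(C)[C@@H](NC(=O)/C=C/c1ccncc1-c1ccc2ccccc2c1)C(=O)O`, "not determined" (no result reported);
compound 3, `O=C(O)CCc1ccncc1-c1ccc2ccccc2c1`, 50.5 nM.

Compound 3 stands at the higher of the two numbers reported for this assay; its nearest neighbour is compound 1, and the step of a 4.8-fold higher number from compound 1 to compound 3 (0.68 log units; beyond the scatter) separates them, a gap beyond the scatter. Compound 2 carries no result, so it gives no help here.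

The next compound, compound 4, is `COC(=O)/C=C/c1ccncc1-c1ccc2ccccc2c1`. It differs from compound 3 in one place: 2-(methoxycarbonyl)ethenyl in place of 2-carboxyethyl on an aromatic carbon. For the measured compounds named here, the only measured step that bears on this change is a 4.8-fold higher number from compound 1 to compound 3 (0.68 log units; beyond the scatter), where the saturated acid of compound 3 gave the higher number and the unsaturated amide of compound 1 the lower. Going by the values given here, compound 4 restores the unsaturation of compound 1 while the acid of compound 3 becomes a methyl ester, so neither compound 1 nor compound 3 is a direct model; the one measured step suggests the number may move back some way toward that of compound 1. The expected step of a 2.3-fold lower number from compound 3 to compound 4 (0.36 log units; beyond the scatter) is therefore a modest decrease in the number. Compound 4 is estimated at 22 nM, with a range from 7 nM to 70 nM.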

Compound 4, half-maximal inhibitory concentration: 40.6 nM
For compound 4 the middle estimate is 1.8-fold (0.27 log units) below the measured one; the measured number falls inside the stated range.
By their numbers in this assay, from the lowest: compound 1; then compounds 4 and 3 (each within the scatter of the next).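

In this assay, 2-(methoxycarbonyl)ethenyl in place of 2-carboxyethyl on this aromatic carbon, opposite the ring nitrogen, gives a 1.2-fold lower number from compound 3 to compound 4 (0.09 log units; within the scatter), so the assay does not separate these two groups, even though they differ in their count of double bonds and in the hydrogen-bond donor of the acid. The comparison with compound 1 adds something new: with the ethenyl chain kept, methoxy in place of amino on the carbonyl carbon gives a 3.9-fold higher number from compound 1 to compound 4 (0.59 log units; beyond the scatter), so the double bond alone does not keep the number as low as that of compound 1, and the group on the carbonyl carbon matters at this position. No measurement is available that explains either result.

The compounds shown do not separate the double bond from the end group, since neither a carboxylic acid on the ethenyl chain nor a primary amide on the saturated chain is among them. They also leave open how a secondary amide, such as an N-methyl amide, or a longer chain ending in a primary amide would compare with compound 1.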